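Methyl in place of chloro in compound 3

The compounds below may be only part of what the source reports. "The series", "measured", "known", "first", "only" and "open" are said of these compounds alone.

In a functional assay on MCF7 cells (Homo sapiens) for cytotoxicity, read by CellTiter-Glo, with a stated time of 5 days (a lower number here means a stronger inhibitor, a higher number a weaker inhibitor), compound 1 (`CC/C(=C(/c1ccc(/C=C/C(=O)O)c(C)c1)c1ccc2[nH]ncc2c1)c1ccccc1`) gives 14 nM, compound 2 (`CC/C(=C(/c1ccc(/C=C/C(=O)O)nc1)c1ccc2[nH]ncc2c1)c1ccccc1`) gives 210 nM and compound 3 (`CC/C(=C(/c1ccc(/C=C/C(=O)O)cc1)c1ccc2[nH]ncc2c1)c1ccccc1Cl`) gives 2 nM. Compound 3 thus holds the lowest number of the three, beyond the scatter against both others. Compound 4 (`CC/C(=C(/c1ccc(/C=C/C(=O)O)cc1)c1ccc2[nH]ncc2c1)c1ccccc1C`) carries methyl in place of chloro on an aromatic carbon, ortho to a large group: methyl in place of chloro on an aromatic carbon. Among the measured compounds shown here, no measured pair isolates this change, so the data give no direct size for it. A small rise in this assay is expected, not beyond the scatter. The estimated step is a 1.5-fold higher number from compound 3 to compound 4 (0.18 log units; within the scatter). Compound 4 is expected at 3 nM, within an estimated range of 1 nM to 10 nM.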

Compound 4, half-maximal inhibitory concentration: 4 nM
Compound 4: the middle estimate sits 1.3-fold (0.12 log units) below what was measured; measured number inside the range.
By their numbers in this assay, from the lowest: compounds 3 and 4 (each within the scatter of the next); then compound 1; then compound 2.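

In this assay, the change from 2-chlorophenyl to 2-methylphenyl is the only one-place comparison shown, and it gives a 2.0-fold higher number from compound 3 to compound 4 (0.30 log units; within the scatter). On this aromatic carbon, ortho to a large group, chloro and methyl therefore cannot be told apart in this read-out. No supporting measurement is available to explain this result.

On these data alone, whether fluoro, methoxy or an amine at this position would also read alike remains open. Also open, as far as these compounds go, is whether the same change would read alike on compound 1 or compound 2.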